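The source may hold more compounds than are shown below. What is called first, only, known or untested is meant among the compounds shown, and "the series" means these compounds.

In a functional assay on HeLa cells (Homo sapiens) for inhibition, read by MTT assay, with a stated time of 72 h (on this read-out higher numbers stand for weaker inhibition and lower numbers for stronger inhibition), compound 3, `CN(C(=O)NC(=O)c1ccc([N+](=O)[O-])cc1)c1nc(C(F)(F)F)c(C(=O)N/N=C/c2cccc(C(F)(F)F)c2)s1`, gives 4.12 ug/mL, the lowest of the numbers recorded. Compound 1, `CN(C(=O)NC(=O)c1c(F)cccc1F)c1nc(C(F)(F)F)c(C(=O)N/N=C/c2cccc(C(F)(F)F)c2)s1`, gives 21.6 ug/mL in this assay, so that a 5.2-fold lower number from compound 1 to compound 3 (0.72 log units; beyond the scatter). For compound 2, `CNc1nc(C(F)(F)F)c(C(=O)N/N=C/c2cccc(C(F)(F)F)c2)s1`, this assay reports only a limit, > 100 ug/mL, as noted in the limit of > 100 ug/mL in this assay, at which 1 of the 3 values shown sits. Compound 4, `CN(C(=O)NC(=O)c1ccccc1F)c1nc(C(F)(F)F)c(C(=O)N/N=C/c2cccc(C(F)(F)F)c2)s1`, carries 2-fluorophenyl in place of 4-nitrophenyl on a carbonyl carbon. Within the data shown here, the only measured step that bears on this place is the one from compound 1 to compound 3, and compound 4 resembles compound 1 more closely than compound 3 in that place, so the number is expected to move back upward by a step beyond the scatter, though perhaps not as far as compound 1. Compound 4 is therefore expected to give 14 ug/mL in this assay, within 5 ug/mL to 45 ug/mL. That estimate means an expected step of a 3.4-fold higher number from compound 3 to compound 4 (0.53 log units; beyond the scatter).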

Compound 4, half-maximal inhibitory concentration: 19.1 ug/mL
Compound 4: the middle estimate sits 1.4-fold (0.13 log units) below what was measured; low and high end bracket the measured number.
By their numbers in this assay, from the lowest: compound 3; then compounds 4 and 1 (each within the scatter of the next). At a limit, above all of these: compound 2.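

The step of a 4.6-fold higher number from compound 3 to compound 4 (0.67 log units; beyond the scatter) shows that the lower number seen with 4-nitrophenyl on this carbonyl carbon does not carry over to 2-fluorophenyl. With a 1.1-fold lower number from compound 1 to compound 4 (0.05 log units; within the scatter), hydrogen in place of fluoro on an aromatic carbon leaves compound 1 and compound 4 within the scatter of each other. With compound 2 at a limit, the ((2-fluorophenyl)carbonyl)carbamoyl group in place of hydrogen on the nitrogen reads only as an at least 5.2-fold lower number from compound 2 to compound 4 (0.71 log units; beyond the scatter): the limit of > 100 ug/mL in this assay, at which 1 of the 4 values shown sits.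

The compounds shown do not separate the nitro group itself from its place on the ring. A 2-nitrophenyl or 4-aminophenyl group on this carbonyl carbon would bear on both questions.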